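A few compounds are considered here, and "the series" means these few. Any claim that something is new, unique, unknown or untested is made for them only; others in the source may bear on it.

Measured compounds:
Compound 1 `O=S(=O)(Nc1ccc(-c2nc3ccccc3o2)cc1)c1cccc(Cl)c1` — in an assay on isolated protein for inhibition of malate dehydrogenase, mitochondrial (Sus scrofa), with stated times of 45 min and 30 min (a lower number here means a stronger inhibitor, a higher number a weaker inhibitor), compound 1 gives > 63000 nM, which is a limit of the assay and not a number.
Compound 2 `COc1ccccc1S(=O)(=O)Nc1ccc2oc(-c3ccccc3)nc2c1` — in this assay compound 2 gives > 63000 nM, again a limit rather than a measured number.
Compound 3 `O=S(=O)(Nc1ccc2oc(-c3ccccc3)nc2c1)c1ccc(C(F)(F)F)cc1` — in this assay compound 3 gives > 63000 nM, also a limit.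

All three compounds share the same core, a sulfonamide attached to an aromatic system, and they differ only in the group on the sulfonyl sulfur and in where the sulfonamide sits. None of them shows measurable inhibition: each value is the upper limit of what this assay can report (the limit of > 63000 nM in this assay, at which 3 of the 3 values shown sit). Compound 2 therefore stands nowhere distinct among the numbers shown; it sits at the same limit as the other two, and no ranking among them is possible.

Compound 4 `CS(=O)(=O)Nc1ccc2oc(-c3ccccc3)nc2c1` differs from compound 2 in one place: methyl in place of 2-methoxyphenyl on a sulfonyl sulfur. No change between measured compounds is available to say how this kind of swap affects potency. Given that compound 2 gives > 63000 nM and that the other compounds give only limits, a step from compound 2 to compound 4 of a step that the limit leaves unreadable from compound 2 to compound 4 is expected, meaning no measurable gain. Compound 4 is expected to give about 100000 nM, with a range from 30000 nM to 300000 nM, most likely reported again as a limit.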

Compound 4, half-maximal inhibitory concentration: > 63000 nM
Compound 4: only a limit was reported (the forecaster's own chance of this, stated with the estimate: 85%); the middle value does not contradict the limit.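

No step can be read from compound 2 to compound 4, because both results are limits of the assay and not numbers: the limit of > 63000 nM in this assay, at which 4 of the 4 values shown sit.

The compounds shown leave open how these four rank against one another, and whether any other group on the sulfonyl sulfur, or any change to the shared core, would give a measurable value.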